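The source may report more compounds than this note shows. Statements on the series, on what has been measured and on what is new or still open speak of the compounds shown alone.

In a functional assay on NCI-H460 cells (Homo sapiens) for inhibition, with a stated time of 72 h (a lower number here means a stronger inhibitor, a higher number a weaker inhibitor), three compounds sharing one core have been measured. Compound 1 (`COc1ccc(S(=O)(=O)N2CCc3cccc(-c4ccc([N+](=O)[O-])cc4)c32)cc1`) gives 53.1 nM, compound 2 (`COc1ccc(S(=O)(=O)N2CCc3cccc(-c4ccc(N(C)C)cc4)c32)cc1`) gives 556 nM and compound 3 (`COc1ccc(S(=O)(=O)N2CCc3cccc(-c4cc(OC)c(OC)c(OC)c4)c32)cc1`) gives 6340 nM. Compound 2 therefore holds the middle place, second highest of the three numbers. Still unmeasured is compound 4 (`COc1ccc(S(=O)(=O)N2CCc3cccc(-c4cccnc4)c32)cc1`), which differs from compound 2 as follows: pyridin-3-yl in place of 4-(dimethylamino)phenyl on an aromatic carbon. In words, pyridin-3-yl stands in place of 4-(dimethylamino)phenyl on an aromatic carbon. Within the data shown here, only one measured step bears on this change: a 10-fold higher number from compound 1 to compound 2 (1.02 log units; beyond the scatter), a large step beyond the scatter, with dimethylamino in place of nitro on an aromatic carbon. That step shows how far the number can move with a single change, but it leaves the carbon-only ring in place, so it is a weak guide to direction here. A modest move towards a weaker inhibitor is expected, with wide uncertainty. The expected change is a 2.2-fold higher number from compound 2 to compound 4 (0.33 log units; beyond the scatter), close to the scatter. For compound 4 the estimated value is 1200 nM, with an expected range from 250 nM to 5500 nM.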

Compound 4, half-maximal inhibitory concentration: 89.6 nM
For compound 4 the middle estimate is 13-fold (1.13 log units) above the measured one; the measured number lies below the stated range.
By their numbers in this assay, from the lowest: compounds 1 and 4 (each within the scatter of the next); then compound 2; then compound 3.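

In this assay the change from 4-(dimethylamino)phenyl to pyridin-3-yl gives a 6.2-fold lower number from compound 2 to compound 4 (0.79 log units; beyond the scatter) and shows that, at this place on the shared core, a low number does not need a ring of carbon only. The change from 4-nitrophenyl to pyridin-3-yl gives a 1.7-fold higher number from compound 1 to compound 4 (0.23 log units; within the scatter) and stays within the scatter, so two different rings, one with a hetero atom and one of carbon only, cannot be told apart here. No measured information available here accounts for this result.

The compounds shown leave open whether the ring nitrogen's place matters, as pyridin-2-yl or pyridin-4-yl would show. They also leave open how plain phenyl, or a phenyl ring bearing a carboxylic acid or a primary amine, would fare at this place.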